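A few compounds are considered here, and "the series" means these few. Any claim that something is new, unique, unknown or untested is made for them only; others in the source may bear on it.

Working notes on the series of compound 1 `CC(C)(C)N(NC(=O)c1cccc(Br)c1)C(=O)c1ccccc1Cl` and compound 2 `COc1cccc(C(=O)NN(C(=O)c2ccccc2Cl)C(C)(C)C)c1C`, with compound 3 `Cc1ccc(C(=O)NN(C(=O)c2ccccc2Cl)C(C)(C)C)c(C)c1` still to be measured.

In an assay on cells for agonist activity at ecdysone receptor (Bombyx mori), read by a luciferase reporter, with a stated time of 24 h (on this read-out higher numbers stand for an effect only at larger amounts of compound and lower numbers for an effect already at smaller amounts), compound 1 gives 191 nM. Compound 2 gives 15.5 nM in this assay. Within the data shown here, of the two numbers known, compound 1 stands highest, and the gap to compound 2 is beyond the scatter of repeated measurements.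

The step from compound 1 to compound 3 changes one place on the core shared by both: 2,4-dimethylphenyl in place of 3-bromophenyl on a carbonyl carbon. Among the measured compounds shown here, no measured pair in the set differs only in this way, so the size of the step is not yet known.

Because compound 2 reaches 15.5 nM with a differently substituted ring on the same carbonyl carbon, the number for compound 3 is expected to move downward from that of compound 1 by a step beyond the scatter, roughly a 6.4-fold lower number from compound 1 to compound 3 (0.80 log units; beyond the scatter). For compound 3 the estimate in this assay is 30 nM, with a range from 8 nM to 120 nM.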

Compound 3, half-maximal effective concentration: 162 nM
Compound 3: the middle estimate sits 5.4-fold (0.73 log units) below what was measured; the whole stated range lies below it.
By their numbers in this assay, from the lowest: compound 2; then compounds 3 and 1 (each within the scatter of the next).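

The exchange of 3-bromophenyl for 2,4-dimethylphenyl on a carbonyl carbon gives, in this assay, a 1.2-fold lower number from compound 1 to compound 3 (0.07 log units; within the scatter), the first step read at this place, and this read-out does not separate the two groups. The value of compound 2, 15.5 nM, therefore does not carry over to every other substituted phenyl on this carbonyl carbon, as compound 3 gives 162 nM. No independent measurement bears on this result, so the closeness of compound 1 and compound 3 remains unexplained.

Which of the substituents on the phenyl ring of compound 2 goes with its value stays open; no compound shown varies them singly. Also open, from the compounds shown here alone, is how this assay responds at this carbonyl carbon to a phenyl ring carrying an amine or a carboxylic acid, or to a longer alkyl chain in place of the ring.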